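The source may report more compounds than this note shows. Statements on the series, on what has been measured and on what is new or still open speak of the compounds shown alone.

For the measured compounds named here, in a functional assay on DU-145 cells (Homo sapiens) for inhibition (on this read-out higher numbers stand for weaker inhibition and lower numbers for stronger inhibition), compound 3 `CCOc1ccc(Cl)cc1-c1cc(Nc2ccc([N+](=O)[O-])cc2)nc(N)n1` gives 350 nM, the only actual number in this small set. Compound 1 `CCOc1ccc(Br)cc1-c1cc(Nc2cccc(C#N)c2)nc(N)n1` reaches only a limit of the assay, > 1000 nM. Compound 2 `CCOc1ccc(Cl)cc1-c1cc(Nc2ccc(CCCO)cc2)nc(N)n1` likewise reaches only a limit, > 1000 nM. Compound 4 `CCOc1ccc(Cl)cc1-c1cc(Nc2ccc3c[nH]nc3c2)nc(N)n1` is the next to be read, and it carries one structural change from compound 3: 2H-indazol-6-yl in place of 4-nitrophenyl on a nitrogen on an aromatic ring. Going by the values given here, the one measured step that bears on this change is an at least 2.8-fold lower number from compound 2 to compound 3 (0.45 log units; beyond the scatter), which shows that a swap of a single group can shift the number but says nothing about the indazolyl group. No step beyond the scatter is therefore expected in this assay, and the expected step is a 1.1-fold higher number from compound 3 to compound 4 (0.06 log units; within the scatter). Compound 4 is estimated at 400 nM, with an expected range of 80 nM to 1800 nM.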

Compound 4, half-maximal inhibitory concentration: 200 nM
Beside the measured number, compound 4's estimate is 2.0-fold (0.30 log units) above it; low and high end bracket the measured number.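

In this assay, the change from 4-nitrophenyl to 2H-indazol-6-yl is a 1.8-fold lower number from compound 3 to compound 4 (0.24 log units; within the scatter), so on this nitrogen a two-ring group carrying a hydrogen-bond donor serves as well as the nitro-bearing ring. Compound 4 thus gives an actual number without any nitro group. Actual numbers remain few, however: the limit of > 1000 nM in this assay, at which 2 of the 4 values shown sit.

The compounds shown leave open whether a simple amine or a carboxylic acid on the phenyl ring would give a number in the same range. They also leave open whether an indole, with carbon in place of the second ring nitrogen, would do so.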